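One Aryl Swap on a Shared Core: What to Expect

The compounds below may be only part of what the source reports. "The series", "measured", "known", "first", "only" and "open" are said of these compounds alone.

Of the compounds shown here, three have so far been measured in a functional assay on BCG823 cells (Homo sapiens) for inhibition, read by MTT assay, with a stated time of 72 h; a higher number here means a weaker inhibitor, a lower number a stronger inhibitor.

Compound 1, `CN(C(=O)NC(=O)c1cccc(C(F)(F)F)c1)c1nc(C(F)(F)F)c(C(=O)N/N=C/c2ccc(C(F)(F)F)cc2)s1`, gives 4.22 ug/mL.
Compound 2, `CN(C(=O)NC(=O)c1c(F)cccc1F)c1nc(C(F)(F)F)c(C(=O)N/N=C/c2cccc(C(F)(F)F)c2)s1`, gives 25.9 ug/mL.
Compound 3, `CN(C(=O)NC(=O)c1ccc(F)c(F)c1)c1nc(C(F)(F)F)c(C(=O)N/N=C/c2cc(C(F)(F)F)cc(C(F)(F)F)c2)s1`, gives 3.51 ug/mL.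

Among the three, compound 3 has the lowest number, but its gap to compound 1 lies within the scatter of repeated measurements, so these two cannot be separated in this assay. Only compound 2 stands clearly apart, beyond the scatter above both of the others.

Compound 4, `CN(C(=O)NC(=O)c1ccc(C(F)(F)F)cc1)c1nc(C(F)(F)F)c(C(=O)N/N=C/c2cc(C(F)(F)F)cc(C(F)(F)F)c2)s1`, has not yet been measured. It differs from compound 3 in one place: 4-(trifluoromethyl)phenyl in place of 3,4-difluorophenyl on a carbonyl carbon. For the measured compounds named here, no measured pair of compounds differs by exactly this change, so there is no directly comparable step to lean on. Going by the values given here, the only hint comes from compound 1, which also carries a phenyl ring bearing a single trifluoromethyl group and sits within the scatter of compound 3 because compound 1 gives 4.22 ug/mL. On that basis the step from compound 3 to compound 4 is expected to be small, a 1.1-fold higher number from compound 3 to compound 4 (0.06 log units; within the scatter), with no clear direction beyond the scatter. Compound 4 is therefore estimated at 4 ug/mL, with a likely range from 1.5 ug/mL to 12 ug/mL.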

Compound 4, half-maximal inhibitory concentration: 1.77 ug/mL
Compound 4: the middle estimate sits 2.3-fold (0.35 log units) above what was measured, and the stated range covers the measured number.
By their numbers in this assay, from the lowest: compounds 4, 3 and 1 (each within the scatter of the next, the first and the last beyond it); then compound 2.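

In this assay, putting 4-(trifluoromethyl)phenyl in place of 3,4-difluorophenyl on a carbonyl carbon whose other neighbour is an amide-type nitrogen gives a 2.0-fold lower number from compound 3 to compound 4 (0.30 log units; within the scatter), the only measured step at this position among the compounds shown. This position therefore accepts either aryl group, one with 8 heavy atoms and two fluorines on the ring and the other with 10 heavy atoms and a trifluoromethyl group, and the assay cannot separate the two, so the step gives no ranking of these groups. No measured property of either group is available to account for this result.

For the compounds shown here, this single step covers only two halogen-bearing phenyl rings with the same partner elsewhere on the shared core, so it remains open whether the same swap would read alike with a different aryl group at that other site. Going by these compounds, it also remains open how the number would respond at this position to a ring carrying an amine or a carboxylic acid, or to a butyl chain in place of the ring.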